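Swapping the sulfonyl aryl group: from methoxyphenyl to cyanophenyl

The compounds below may be only part of what the source reports. "The series", "measured", "known", "first", "only" and "open" are said of these compounds alone.

Measured compounds in an assay on isolated protein for displacement of a labelled ligand from metabotropic glutamate receptor 5 (Homo sapiens), with a stated time of 60 min, tested at 1 uM; on this read-out higher numbers stand for more inhibition at the one concentration tested (going by the name of the read-out) and lower numbers for less inhibition:
compound 1, `COc1ccc(S(=O)(=O)c2cnc3ccc(C)cc3c2N2CCC(C)CC2)cc1`, gives 62%
compound 2, `COc1ccc(S(=O)(=O)c2cnc3ccc(OC)cc3c2N2CCC(C)CC2)cc1`, gives 41%
compound 3, `CC1CCN(c2c(S(=O)(=O)c3cccc(Cl)c3)cnc3cc(Cl)ccc23)CC1`, gives 92%

Compound 1 stands second highest of the three numbers in this assay. Its nearest neighbour is compound 2, with a number 21 percentage points lower from compound 1 to compound 2 (beyond the scatter), a change that rests on a methoxy in place of methyl on an aromatic carbon. Compound 3 lies furthest away, its number well above that of compound 1; compound 3 differs from compound 1 in more than one place, so only the two values themselves can be compared.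

Compound 4, `Cc1ccc2ncc(S(=O)(=O)c3cccc(C#N)c3)c(N3CCC(C)CC3)c2c1`, is not yet measured. It differs from compound 1 as follows: 3-cyanophenyl in place of 4-methoxyphenyl on a sulfonyl sulfur. Among the compounds with values here, no measured step touches this particular change, since the only single-point step available, from compound 1 to compound 2, concerns a different part of the molecule. Within the data shown here, the one compound carrying a differently substituted phenyl on the sulfonyl sulfur, compound 3, gives the highest number seen, but its second change makes it no direct guide.

Among the measured compounds shown here, with no step bearing on the change, compound 4 is expected to sit near compound 1 or somewhat above it, the estimated step being a number 8 percentage points higher from compound 1 to compound 4 (within the scatter). Compound 4 is therefore estimated at 70%, within 45% to 90%.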

Compound 4, a percentage reported as inhibition, at one concentration (the size of the read-out at that concentration, not a potency): 52%
For compound 4 the middle estimate is 18 percentage points above the measured one; the measured number falls inside the stated range.
By their numbers in this assay, from the lowest: compound 2; then compounds 4 and 1 (each within the scatter of the next); then compound 3.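

In this assay, within the data shown here, this is the first single-place comparison at the aryl group on the sulfonyl sulfur: 3-cyanophenyl in place of 4-methoxyphenyl gives a number 10 percentage points lower from compound 1 to compound 4 (within the scatter) on this read-out. The earlier step concerned a different part of the molecule, and compound 3 carries a second change, so neither could show that these two aryl groups cannot be told apart here, with the rest of compound 1 kept unchanged. Nothing measured here gives a reason for this result.

The exchange alters both the group on the phenyl ring and its place, so the compounds shown leave open whether either alteration alone would have a larger effect, which the methoxy and the nitrile each carried at the other's place on the phenyl could separate. Also open, from the compounds shown here alone, is how an amine or a carboxylic acid on that phenyl would read on the core of compound 1, and whether the chlorine-bearing aryl group of compound 3 would keep its high number on that core without the second change.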